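The source may hold more compounds than are shown below. What is called first, only, known or untested is meant among the compounds shown, and "the series" means these compounds.

Measured compounds:
Compound 1 `Cc1ccc(C)c(S(=O)(=O)n2c(-c3cn(-c4ccccc4)nc3-c3ccc(F)cc3)nc3ccccc32)c1` gives 122000 nM in an ADME assay on cells (Hepatocyte, Mus musculus) for cytotoxicity, read by MTT assay, with a stated time of 24 h; on this read-out lower numbers stand for higher toxicity in this test and higher numbers for lower toxicity in this test.
Compound 2 `O=[N+]([O-])c1ccc(S(=O)(=O)n2c(-c3cn(-c4ccccc4)nc3-c3ccc(F)cc3)nc3ccccc32)cc1` gives in this assay only a limit of the assay, > 300000 nM.
Compound 3 `Cc1ccc(C)c(S(=O)(=O)n2c(-c3cn(-c4ccccc4)nc3-c3ccc(C(F)(F)F)cc3)nc3ccccc32)c1` gives 132000 nM in this assay.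

Compound 1 and compound 3 share the same core and differ in a single group: trifluoromethyl in place of fluoro on an aromatic carbon. This change yields a 1.1-fold higher number from compound 1 to compound 3 (0.03 log units; within the scatter), so the two values cannot be told apart in this assay.

Between compound 1 and compound 2 the change is different: 4-nitrophenyl in place of 2,5-dimethylphenyl on a sulfonyl sulfur. The step here is an at least 2.4-fold higher number from compound 1 to compound 2 (0.39 log units; beyond the scatter). It is known only as a lower bound because of the limit of > 300000 nM in this assay, at which 1 of the 3 values shown sits, which is where compound 2 sits, so the true size of this step may be larger than the number given.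

Compound 4 `O=[N+]([O-])c1ccc(S(=O)(=O)n2c(-c3cn(-c4ccccc4)nc3-c3ccc(C(F)(F)F)cc3)nc3ccccc32)cc1` has not yet been measured in this assay. It relates to compound 3 exactly as compound 2 relates to compound 1: 4-nitrophenyl in place of 2,5-dimethylphenyl on a sulfonyl sulfur. The place of the change is the same word for word in both pairs, so this is the same change seen a second time. The step from compound 3 is expected to be a 2.4-fold higher number from compound 3 to compound 4 (0.38 log units; beyond the scatter), resting on the step from compound 1 to compound 2 and on compound 1 and compound 3 being indistinguishable in this assay. Compound 4 is therefore estimated at 320000 nM, expected to fall between 200000 nM and 520000 nM, with a real chance that this assay again reports only a limit.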

Compound 4, half-maximal cytotoxic concentration: 178000 nM
Compound 4: middle estimate off by 1.8-fold (0.25 log units), on the high side; measured number below the stated range.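

Swapping 2,5-dimethylphenyl for 4-nitrophenyl on the sulfonyl sulfur gives a 1.3-fold higher number from compound 3 to compound 4 (0.13 log units; within the scatter) in this assay, so on the trifluoromethyl core this change leaves no step that stands out from the scatter, and beside the first pair the picture is: the same change on two cores in this assay, an at least 2.4-fold higher number (0.39 log units; beyond the scatter) from compound 1 to compound 2 and a 1.3-fold higher number (0.13 log units; within the scatter) from compound 3 to compound 4; the limit leaves it open whether they differ

Swapping fluoro for trifluoromethyl with 4-nitrophenyl in place gives an at least 1.6-fold lower number from compound 2 to compound 4 (0.22 log units; that floor lies within the scatter), and beside the matching pair with 2,5-dimethylphenyl this comparison also stays unsettled: the same change on two cores in this assay, a 1.1-fold higher number (0.03 log units; within the scatter) from compound 1 to compound 3 and an at least 1.6-fold lower number (0.22 log units; that floor lies within the scatter) from compound 2 to compound 4; the limit leaves it open whether they differ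

The value of compound 2, > 300000 nM, is a limit of the assay and not a number, so these pairs show neither that the sulfonyl change carries over from one core to the other at the same size nor that it fails to.

The compounds shown leave open how other groups on the sulfonyl sulfur, such as an aminophenyl, a methoxyphenyl or a plain methyl, would read in this assay. Among the compounds shown here, with only two groups tried at each of the two places, they also leave open whether any trend holds across a wider set, for example with chloro or a nitrile in place of fluoro.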